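The source may hold more compounds than are shown below. What is called first, only, known or untested is meant among the compounds shown, and "the series" means these compounds.

Compound 1, `Cc1nc(-c2ccc(Cl)cc2)sc1C(=O)CSc1nc(N)c(C#N)c(-c2ccc(Cl)cc2)n1`, is one of three compounds examined in a functional assay on U-87MG ATCC cells for antiproliferative activity against U-87 MG (Homo sapiens), read by MTT assay, with a stated time of 48 h, tested at 100 uM (on this read-out lower numbers stand for a stronger effect and higher numbers for a weaker effect at the one concentration tested), where compound 1 gives 1.65%. The second, compound 2, `COc1ccc(-c2nc(C)c(C(=O)CSc3nc(-c4ccc(OC)cc4)c(C#N)c(=O)[nH]3)s2)cc1`, gives 11.5% in this assay, and the third, compound 3, `Cc1nc(-c2ccccc2)sc1C(=O)CSc1nc(-c2ccccc2)c(C#N)c(=O)[nH]1`, gives 9.23%. As written, compound 1 carries the smallest of the three numbers, yet the gap to compound 3 and the gap to compound 2 both fall within the usual scatter of this kind of measurement, so the three compounds cannot be told apart on these data.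

The next compound, compound 4, `COc1ccc(-c2nc(C)c(C(=O)CSc3nc(N)c(C#N)c(-c4ccc(Cl)cc4)n3)s2)cc1`, differs from compound 1 in one place: methoxy in place of chloro on an aromatic carbon. Among the measured compounds shown here, no pair of measured compounds shows this change on its own, so its size has to be judged without a direct precedent. Given that all three measured compounds sit close together in this assay, the change is expected to move the number little, with any shift lying within the scatter and not beyond it; the step from compound 1 to compound 4 is estimated at a number 3.4 percentage points higher from compound 1 to compound 4 (within the scatter). Compound 4 is accordingly expected to give about 5% in this assay, with a range from 0% to 20%.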

Compound 4, a percentage reported as activity, at one concentration (the size of the read-out at that concentration, not a potency): 3.9%
For compound 4 the middle estimate is 1.1 percentage points above the measured one, and the stated range covers the measured number.
By their numbers in this assay, from the lowest: compounds 1, 4, 3 and 2 (each within the scatter of the next).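

In this assay, the exchange of 4-chlorophenyl for 4-methoxyphenyl gives a number 2.3 percentage points higher from compound 1 to compound 4 (within the scatter). Among the compounds shown here, this is the first reading of a single change, since the earlier compounds differ from one another in more than one place, and it shows that at this place, on an aromatic carbon of a six-membered aromatic ring of carbon only and para to a large group, methoxy in place of chloro has no effect that can be told from the scatter at the one concentration tested. The data offer no measurement that could explain this result.

From the compounds shown here alone, the result covers only these two groups at this place, so what a carboxylic acid, a dimethylamino group or a longer alkoxy chain would do there remains open, as does the effect of the same exchange on the other 4-chlorophenyl group of compound 1, which compound 4 keeps. With a single concentration as the only read-out, the step also says nothing about whether the two compounds differ in potency.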